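Triazole ethers: nitro to chloro on A549 growth

The compounds below may be only part of what the source reports. "The series", "measured", "known", "first", "only" and "open" are said of these compounds alone.

Compound 1 `O=[N+]([O-])c1cccc(Cn2cc(COc3ccc(Cl)cc3)nn2)c1` carries a nitro group on its benzyl ring. In an ADME assay on A549 cells (Homo sapiens) for inhibition, read by MTT assay, with a stated time of 48 h (on this read-out higher numbers stand for weaker inhibition of growth and lower numbers for stronger inhibition of growth), compound 1 returns only a limit, > 100 ug/mL. Compound 2 `Clc1ccc(OCc2cn(Cc3cccc(Cl)c3)nn2)cc1` differs by chloro in place of nitro on an aromatic carbon. In this assay compound 2 likewise returns a limit, > 100 ug/mL. The step that the two limits leave unreadable from compound 1 to compound 2 cannot be sized because of the limit of > 100 ug/mL in this assay, at which 3 of the 3 values shown sit. Compound 3 `Cc1cc(OCc2cn(Cc3ccc([N+](=O)[O-])cc3)nn2)ccc1Cl` has a different core; the difference between the two cores is not broken down here. In this assay compound 3 also returns only a limit, > 100 ug/mL. Compound 4 `Cc1cc(OCc2cn(Cc3ccc(Cl)cc3)nn2)ccc1Cl`, not yet measured, differs from compound 3 by chloro in place of nitro on an aromatic carbon, the same kind of change as from compound 1 to compound 2, though sited para to a large group rather than meta to a large group. A step of a number no higher from compound 3 to compound 4 (the limit leaves the size open) is expected, resting on compound 3 at its limit of > 100 ug/mL. For compound 4 the estimate is 100 ug/mL, between 50 ug/mL and 200 ug/mL, most likely again reported only as a limit.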

Compound 4, concentration for 50% growth inhibition: > 100 ug/mL
Compound 4 gave a limit, no number (the forecaster's own chance of this, stated with the estimate: 85%); the middle value sits exactly at the limit.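

No step can be read from compound 3 to compound 4, because both return only a limit in this assay: the limit of > 100 ug/mL in this assay, at which 4 of the 4 values shown sit. The compounds shown leave open how chloro and nitro compare, and whether any compound here inhibits growth measurably.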